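The source may hold more compounds than are shown below. What is called first, only, known or untested is meant among the compounds shown, and "the series" means these compounds.

Working notes on the series. In a functional assay on HCT-15 cells (Homo sapiens) for antiproliferative activity (on this read-out higher numbers stand for weaker inhibition of growth and lower numbers for stronger inhibition of growth), compound 1 `c1ccc(-c2cc(-c3ccccn3)nc(-c3ccccn3)c2)cc1` gives 0.37 ug/mL and compound 2 `c1ccc(-c2cc(-c3ccco3)cc(-c3ccccn3)n2)nc1` gives 0.1 ug/mL. Within the data shown here, compound 2 therefore holds the lower of the two numbers so far. Compound 3 `c1ccc(-c2cc(-c3ccoc3)cc(-c3ccccn3)n2)nc1` keeps the core of compound 2 and changes only how the furan is attached: furan-3-yl in place of furan-2-yl on an aromatic carbon. The change is furan-3-yl in place of furan-2-yl, on an aromatic carbon opposite the ring nitrogen, meta to two pyridin-2-yl groups.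

Among the measured compounds shown here, one measured step bears on this, and only indirectly: a 3.7-fold lower number from compound 1 to compound 2 (0.57 log units; beyond the scatter), with furan-2-yl in place of phenyl. For the measured compounds named here, that step is modest and replaces one ring type with another, whereas no measured pair compares the two furan attachments. It therefore sets only a loose upper guide for the size of the change. In this assay, a small shift towards a higher number is expected, most likely not beyond the scatter. The estimated step is a 1.5-fold higher number from compound 2 to compound 3 (0.18 log units; within the scatter). For compound 3 the expected value is 0.15 ug/mL, with an estimated range of 0.05 ug/mL to 0.45 ug/mL.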

Compound 3, concentration for 50% growth inhibition: 0.06 ug/mL
Compound 3: the middle estimate sits 2.5-fold (0.40 log units) above what was measured; the measured number falls inside the stated range.
By their numbers in this assay, from the lowest: compounds 3 and 2 (each within the scatter of the next); then compound 1.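

Exchanging the furan attachment on the aromatic carbon opposite the ring nitrogen gives a 1.7-fold lower number from compound 2 to compound 3 (0.22 log units; within the scatter) in this assay and so does not separate furan-3-yl from furan-2-yl on this read-out. Among these compounds, the earlier step from phenyl to furan-2-yl could have depended on that one attachment, but furan-3-yl in place of phenyl gives a 6.2-fold lower number from compound 1 to compound 3 (0.79 log units; beyond the scatter) and lies beyond the scatter as well, so in these three compounds both furan attachments carry lower numbers than phenyl, with no compound going against this. No measured evidence is available here to explain either the match between the two furans or their difference from phenyl.

The compounds shown cover only phenyl and the two furan attachments at this position, so it remains open whether the lower numbers extend to other groups on this carbon, such as an amine, a carboxylic acid or a longer alkyl chain. Going by these compounds, it is also open whether a methyl group on the furan ring would keep the number of compound 3 or shift it beyond the scatter, and whether the order of phenyl and the furans holds in other cell lines.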